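Pendant aryl variation on the shared core: ethyl to bromo

The compounds below may be only part of what the source reports. "The series", "measured", "known", "first", "only" and "open" are said of these compounds alone.

The series keeps the core of compound 1 `c1ccc2c(-c3cn4ccnc4c(-c4ccc5ncn(C6CCCCC6)c5c4)n3)cccc2c1` and varies only the pendant aryl ring. In a physicochemical assay for lipophilicity, using the shake flask method, in phosphate buffer, measured as octanol-water partition, with a stated time of 85 min, at pH 7.4 (on this read-out higher numbers stand for higher lipophilicity and lower numbers for lower lipophilicity), compound 1 gives 1.44. Compound 2 `Cc1cccc(-c2cn3ccnc3c(-c3ccc4ncn(C5CCCCC5)c4c3)n2)c1` gives 1.87 in this assay, and compound 3 `CCc1ccc(-c2cn3ccnc3c(-c3ccc4ncn(C5CCCCC5)c4c3)n2)cc1` gives 1.66. Compound 3 thus stands second highest of the three numbers, although its gaps to both neighbours lie within the scatter: a number 0.21 log units lower from compound 2 to compound 3 (within the scatter), and a number 0.22 log units higher from compound 1 to compound 3 (within the scatter). Going by the values given here, the only step beyond the scatter is a number 0.43 log units higher from compound 1 to compound 2 (beyond the scatter).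

Compound 4 `Brc1ccc(-c2cn3ccnc3c(-c3ccc4ncn(C5CCCCC5)c4c3)n2)cc1` is not yet measured. It differs from compound 3 by bromo in place of ethyl on an aromatic carbon. Among the compounds with values here, no measured step exchanges ethyl for bromo, so the expectation rests on the general spread: the three substituent changes on this ring moved the read-out by a modest amount at most, and the one-group change from a methyl to an ethyl substituent stayed within the scatter. A step of similar size is expected here, with a number 0.11 log units lower from compound 3 to compound 4 (within the scatter) pointing slightly lower but not beyond the scatter. Compound 4 is therefore estimated at 1.55 in this assay, within a range from 1.2 to 1.9.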

Compound 4, partition coefficient: 1.73
Compound 4: middle estimate off by 0.18 log units, on the low side; the measured number falls inside the stated range.
By their numbers in this assay, from the lowest: compounds 1, 3, 4 and 2 (each within the scatter of the next, the first and the last beyond it).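

On the aromatic carbon para to a large group, bromo in place of ethyl gives no resolved change in this assay (a number 0.07 log units higher from compound 3 to compound 4 (within the scatter)), so the two groups cannot be told apart on this read-out, although they differ in atom type and heavy-atom count. Going by these compounds alone, compound 4 also stays within the scatter of both earlier compounds (a number 0.14 log units lower from compound 2 to compound 4 (within the scatter); a number 0.29 log units higher from compound 1 to compound 4 (within the scatter)), which places 4-bromophenyl alongside 4-ethylphenyl, the other group that cannot be separated from either 3-methylphenyl or naphthalen-1-yl, while compound 1 and compound 2 remain the only pair resolved in this small set. No measurement available here accounts for these numbers or for the absence of a resolved step between the two groups at this position.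

Still open, as far as these compounds go, is whether an amine, a carboxylic acid or a longer alkyl chain such as butyl on this same aromatic carbon would give a step beyond the scatter from compound 4 in this assay. A methyl group on this carbon would also show whether the number then falls with compound 3 and compound 4 or stays closer to compound 2.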